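Swapping a Methyl for Hydrogen on a Sulfonamide Amide

A few compounds are considered here, and "the series" means these few. Any claim that something is new, unique, unknown or untested is made for them only; others in the source may bear on it.

Compound 1 `CCC(C)C(C(=O)Nc1ccc(C(C)=O)cc1)N(C(=O)c1ccccc1)S(=O)(=O)c1ccc(C)cc1` gives 47.3% in a functional assay for inhibition, read by spectrophotometry, with a stated time of 20 min, tested at 5 mg/mL; a lower number here means a weaker effect, a higher number a stronger effect of the compound at the concentration tested. Compound 2 `CC(=O)c1ccc(NC(=O)C(C(C)C)N(C(=O)c2ccccc2)S(=O)(=O)c2ccc(C)cc2)cc1` gives 42.7% in this assay. Compound 3 `CCC(C)C(C(=O)Nc1ccc(C(C)=O)cc1)N(C(=O)c1ccccc1)S(=O)(=O)c1ccc([N+](=O)[O-])cc1` gives 53.2% in this assay.

One change has already been seen once: hydrogen in place of methyl on a saturated chain carbon, three bonds along the chain from an amide-type nitrogen and a carbonyl carbon. It moved the result a number 4.6 percentage points lower from compound 1 to compound 2 (within the scatter). Compound 4 `CC(=O)c1ccc(NC(=O)C(C(C)C)N(C(=O)c2ccccc2)S(=O)(=O)c2ccc([N+](=O)[O-])cc2)cc1` is not yet measured; it differs from compound 3 by hydrogen in place of methyl on a saturated chain carbon, three bonds along the chain from an amide-type nitrogen and a carbonyl carbon, which is the same change, made on compound 3 instead of compound 1. The cores of compound 1 and compound 3 differ by nitro in place of methyl on an aromatic carbon, which moved the result a number 5.9 percentage points higher from compound 1 to compound 3 (within the scatter).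

Because the earlier step of a number 4.6 percentage points lower from compound 1 to compound 2 (within the scatter) stayed within the scatter, compound 4 is expected to change the result by about a number 4.2 percentage points lower from compound 3 to compound 4 (within the scatter). Compound 4 is therefore estimated at 49%, with a likely range from 38% to 60%.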

Compound 4, a percentage reported as inhibition, at one concentration (the size of the read-out at that concentration, not a potency): 27.4%
Beside the measured number, compound 4's estimate is 21.6 percentage points above it; measured number below the stated range.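

On the core of compound 3, the swap of sec-butyl to isopropyl moved the result a number 25.8 percentage points lower from compound 3 to compound 4 (beyond the scatter), so the step seen on the core of compound 1 did not carry over in size: the same change on two cores in this assay, a number 4.6 percentage points lower (within the scatter) from compound 1 to compound 2 and a number 25.8 percentage points lower (beyond the scatter) from compound 3 to compound 4, 21.2 percentage points apart, beyond the scatter of two such steps

Read the other way round, nitro in place of methyl gave a step of a number 15.3 percentage points lower from compound 2 to compound 4 (beyond the scatter), which does not match its step on the other core either: the same change on two cores in this assay, a number 5.9 percentage points higher (within the scatter) from compound 1 to compound 3 and a number 15.3 percentage points lower (beyond the scatter) from compound 2 to compound 4, 21.2 percentage points apart, beyond the scatter of two such steps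

These four compounds show that in this assay the two changes do not simply add, but they do not show why, nor how either change would behave on any further core.

Still open, as far as these compounds go, is whether a longer chain in place of the sec-butyl follows the same course on each core. Also open, from the compounds shown here alone, is whether an amine or a carboxylic acid in place of the nitro would give the same dependence on the chain.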